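Chloro to methoxy on the indole core of compound 1

A few compounds are considered here, and "the series" means these few. Any claim that something is new, unique, unknown or untested is made for them only; others in the source may bear on it.

Compound 1, `O=C(Cc1cccnc1)c1cc2cc(Cl)ccc2[nH]1`: 24600 nM
Compound 2, `COc1cccc2[nH]c(C(=O)Cc3cccnc3)cc12`: 58000 nM

In an assay on isolated protein for inhibition of Indoleamine 2,3-dioxygenase 1 (Homo sapiens), read by spectrophotometry (a higher number here means a weaker inhibitor, a lower number a stronger inhibitor), compound 1 gives 24600 nM, the lowest of the two numbers; compound 2 gives 58000 nM, a gap beyond the scatter. Compound 3, `COc1ccc2[nH]c(C(=O)Cc3cccnc3)cc2c1`, is not yet measured. It differs from compound 1 by methoxy in place of chloro on an aromatic carbon. For the measured compounds named here, no measured pair shows this exact change, so the size of the step is uncertain; a small shift toward a higher number, possibly within the scatter, is expected. Compound 3 is estimated at 40000 nM (range 15000 nM to 100000 nM), an expected step of a 1.6-fold higher number from compound 1 to compound 3 (0.21 log units; within the scatter).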

Compound 3, half-maximal inhibitory concentration: 49000 nM
Estimate against measurement, compound 3: 1.2-fold (0.09 log units) below; low and high end bracket the measured number.
By their numbers in this assay, from the lowest: compounds 1, 3 and 2 (each within the scatter of the next, the first and the last beyond it).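

Compound 3 gives the first measured size for methoxy in place of chloro on this aromatic carbon: a 2.0-fold higher number from compound 1 to compound 3 (0.30 log units; within the scatter). In this assay, this exchange therefore does not separate the two groups at this position, even though methoxy adds a hydrogen-bond acceptor and one more heavy atom. No measurement available here accounts for this result. Still open, from the compounds shown here alone, is whether an amine, a carboxylic acid or a longer chain on the same aromatic carbon would give a number clearly apart from that of compound 1.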